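The source may hold more compounds than are shown below. What is called first, only, known or untested is meant among the compounds shown, and "the series" means these compounds.

In a functional assay on MCF7 cells (Homo sapiens) for inhibition, read by sulforhodamine B assay, with a stated time of 48 h (a lower number here means a stronger inhibitor of growth, a higher number a weaker inhibitor of growth), compound 1 `S=C(N/N=C/c1cccs1)Nc1ccc(Cl)cc1` gives > 100000 nM, which is a limit and not a number. Among the measured compounds shown here, compound 2 `CCc1ccc(NC(=S)N/N=C/c2cccs2)cc1` gives > 100000 nM, also a limit, so its position is known only as a limit, and the one other value available is a limit too. For the measured compounds named here, the series so far offers only (the limit of > 100000 nM in this assay, at which 2 of the 2 values shown sit).

Compound 3 `S=C(N/N=C/c1cccs1)Nc1ccc(Br)cc1` differs from compound 2 as follows: bromo in place of ethyl on an aromatic carbon. The bromo group takes the place of ethyl on an aromatic carbon, para to a large group.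

Going by the values given here, the one measured step bearing on this change, a step that the two limits leave unreadable from compound 1 to compound 2, also exchanges a group at an aromatic carbon, and its size cannot be read. It therefore supports no direction, and no change beyond the scatter is expected in this assay. The expected step, a number no higher from compound 2 to compound 3 (the limit leaves the size open), is accordingly small. For compound 3, the estimated value is 100000 nM, with an expected range of 40000 nM to 200000 nM.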

Compound 3, concentration for 50% growth inhibition: < 740 nM
Compound 3: no number, only a limit; the forecaster's own chance of this, stated with the estimate: 75%; at least 130-fold (2.13 log units) between middle value and limit.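

In this assay, the substituent para to a large group on the six-membered aromatic ring now visibly matters: bromo in place of ethyl gives an at least 130-fold lower number from compound 2 to compound 3 (2.13 log units; beyond the scatter), and bromo in place of chloro gives an at least 130-fold lower number from compound 1 to compound 3 (2.13 log units; beyond the scatter). The second step is the sharper finding, since the exchange of one halogen for another separates the two compounds, whereas the step between the two earlier compounds cannot be read. Compound 3 gives < 740 nM, which is a limit and not a number, so both steps have a known minimum size but no exact size.

From the compounds shown here alone, whether the gain is particular to bromo remains open, as iodo, methoxy or an amine at this position would be needed to test it. Going by these compounds, how far compound 3 extends beyond its limit also remains open.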